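The compounds below may be only part of what the source reports. "The series", "measured", "known", "first", "only" and "open" are said of these compounds alone.

In a functional assay on T47D cells (Homo sapiens) for inhibition (on this read-out higher numbers stand for weaker inhibition and lower numbers for stronger inhibition), compound 1 (`Oc1ccc(-c2cc(-c3ccccc3F)cc(-c3ccccc3O)n2)cc1`) gives > 50000 nM, which is a limit of the assay and not a number. Its position is therefore known only as a limit, and any comparison with it carries that uncertainty. Compound 2 (`Oc1ccc(-c2cc(-c3ccccc3F)cc(-c3ccc(O)cc3)n2)cc1`), with 4-hydroxyphenyl in place of 2-hydroxyphenyl on an aromatic carbon, gives 15100 nM. Among the compounds with values here, that is the only measured step here: an at least 3.3-fold lower number from compound 1 to compound 2 (0.51 log units; beyond the scatter), which lies beyond the scatter. It concerns the hydroxyphenyl group, however, and says nothing directly about the group that changes next. Compound 3 (`Oc1ccc(-c2cc(-c3ccccc3C(F)(F)F)cc(-c3ccccc3O)n2)cc1`) retains 2-hydroxyphenyl and instead has trifluoromethyl in place of fluoro on an aromatic carbon, ortho to a large group: trifluoromethyl in place of fluoro on an aromatic carbon. Within the data shown here, no measured step covers this exchange, so no step beyond the scatter is expected in this assay, in either direction. The expected change is an at least 1.1-fold lower number from compound 1 to compound 3 (0.04 log units; that floor lies within the scatter), and a report of only a limit would be no surprise. For compound 3, the estimated value is 45000 nM, with an expected range from 18000 nM to 100000 nM.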

Compound 3, half-maximal inhibitory concentration: 7180 nM
Beside the measured number, compound 3's estimate is 6.3-fold (0.80 log units) above it, outside the stated range (below it).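

In this assay, exchanging fluoro for trifluoromethyl on the aromatic carbon ortho to a large group, with 2-hydroxyphenyl retained, gives an at least 6.9-fold lower number from compound 1 to compound 3 (0.84 log units; beyond the scatter). The earlier step concerned only the hydroxyphenyl group, whereas this result shows that a second place on the core of compound 1 can also shift the read-out beyond the scatter, here towards stronger inhibition. The true size of the new step remains unknown, however, because compound 1 stands at a limit of the assay and not at a number: the limit of > 50000 nM in this assay, at which 1 of the 3 values shown sits.

The compounds shown leave open whether the gains from 4-hydroxyphenyl and from trifluoromethyl would add up on one molecule, since each change is seen only on its own against compound 1, and no compound here carries both. They also leave open what decides the effect at this position, since only fluoro and trifluoromethyl appear there, and neither a chloro group, a methoxy group, a nitrile nor a longer chain such as ethyl or propyl is among the compounds shown.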